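The source may report more compounds than this note shows. Statements on the series, on what has been measured and on what is new or still open speak of the compounds shown alone.

Measured compounds:
compound 1, `O=C(O)CCc1ccc(C#Cc2cccs2)cc1`: 97%
compound 2, `O=C(O)CCc1ccc(C#Cc2ccc(Cl)nc2)cc1`: 98%
compound 3, `Cc1cnc(Cl)nc1C#Cc1ccc(CCC(=O)O)cc1`: 121%

These three compounds were tested in an in vitro functional assay on 1321-N1 cells for agonist activity at Free fatty acid receptor 1 (Homo sapiens), read by fluorescence, spectrophotometry and calcium flux; a higher number here means a larger maximal response, a lower number a smaller maximal response. Compound 1 sits at the low end of the three numbers, but compound 2 gives a value that lies within the scatter of it, so the two cannot be told apart; only compound 3 stands beyond the scatter above compound 1.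

Compound 4, `O=C(O)CCc1ccc(C#Cc2ccncc2)cc1`, is not yet measured. It differs from compound 1 in one place: pyridin-4-yl in place of thiophen-2-yl on a triple-bonded carbon. Compound 2, which also carries a six-membered ring with one nitrogen on the triple-bonded carbon, gives 98% in this assay, close to compound 1. On that basis no step beyond the scatter is expected, and the change a number 1 percentage points higher from compound 1 to compound 4 (within the scatter) is estimated to be small. Compound 4 is therefore expected to give about 98%, within a range of 80% to 116%.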

Compound 4, largest response reached (reported as efficacy), in percent of the reference or control that the assay uses: 100%
Compound 4: middle estimate off by 2 percentage points, on the low side, within the range that was stated.
By their numbers in this assay, from the lowest: compounds 1, 2 and 4 (each within the scatter of the next); then compound 3.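

Placing pyridin-4-yl instead of thiophen-2-yl on the triple-bonded carbon gives a number 3 percentage points higher from compound 1 to compound 4 (within the scatter). This single change shows that, at this place, a six-membered aromatic ring with one nitrogen and a five-membered aromatic ring with one sulfur cannot be told apart by their maximal response. Nothing shown here explains this similarity.

The compounds shown leave open what a plain phenyl ring or a saturated cyclohexyl ring would give on the same carbon, and so whether a hetero atom in the ring matters at all.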